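The compounds below may be only part of what the source reports. "The series", "measured", "known", "first", "only" and "open" are said of these compounds alone.

Compound 1 `O=C1/C(=C/c2ccccc2)CCC/C1=C\c1cccc([N+](=O)[O-])c1`: 1700 nM
Compound 2 `O=C1/C(=C/c2ccc(Cl)cc2)CCC/C1=C\c1ccccc1[N+](=O)[O-]`: 3860 nM
Compound 3 `O=C1/C(=C/c2ccc(Cl)cc2)CCC/C1=C\c1cccc([N+](=O)[O-])c1`: 2020 nM

All three compounds were tested in a functional assay on MOLT-4 cells (Homo sapiens) for cytotoxicity, with a stated time of 72 h; a lower number here means a stronger inhibitor, a higher number a weaker inhibitor. Compound 1 and compound 3 differ in a single place: hydrogen in place of chloro on an aromatic carbon. The step that goes with this change is a 1.2-fold lower number from compound 3 to compound 1 (0.07 log units; within the scatter), so the two numbers cannot be told apart in this assay.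

Compound 2 and compound 3 are built from the same atoms joined differently; the difference between the two cores is not broken down here. The number for compound 2 lies within the usual scatter of the number for compound 3, but beyond it when set against the number for compound 1.

Compound 4 `O=C1/C(=C/c2ccccc2)CCC/C1=C\c1ccccc1[N+](=O)[O-]` has not yet been measured. It is related to compound 2 in exactly the way that compound 1 is related to compound 3: hydrogen in place of chloro on an aromatic carbon. The place of the change is the same in both pairs, so this is the same change, made this time on the core of compound 2. Because the earlier step was a 1.2-fold lower number from compound 3 to compound 1 (0.07 log units; within the scatter), the step from compound 2 to compound 4 is expected to be small as well, estimated as a 1.2-fold lower number from compound 2 to compound 4 (0.07 log units; within the scatter). On that basis compound 4 is expected to give about 3300 nM in this assay, with a likely range from 1600 nM to 6500 nM; this estimate rests on a single measured example of the change and carries matching uncertainty.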

Compound 4, half-maximal inhibitory concentration: 1480 nM
Compound 4: middle estimate off by 2.2-fold (0.35 log units), on the high side; the whole stated range lies above it.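

In this assay, replacing 4-chlorophenyl with phenyl on the core of compound 2 gives a 2.6-fold lower number from compound 2 to compound 4 (0.42 log units; beyond the scatter), a modest step that, taken alone, is larger than repeated measurements would normally produce. Among these compounds, although only this step lies beyond the usual scatter, it cannot be told apart from the earlier step made on the other core: the same change on two cores in this assay, a 1.2-fold lower number (0.07 log units; within the scatter) from compound 3 to compound 1 and a 2.6-fold lower number (0.42 log units; beyond the scatter) from compound 2 to compound 4, 2.2-fold (0.34 log units) apart, within the scatter of two such steps This means the two results fit a change of similar size on both cores, but two pairs cannot prove that the change carries over unaltered, and they do not show why the number moves or what would happen on a further core.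

The compounds shown have only chloro or hydrogen at this place on the ring, so it remains open how a different group there, such as fluoro, methoxy or an amine, would read in this assay. Also open, as far as these compounds go, is whether the same pattern would hold if the nitro group on the other ring were replaced by another group, such as a carboxylic acid or a nitrile.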